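The source may hold more compounds than are shown below. What is called first, only, known or untested is meant among the compounds shown, and "the series" means these compounds.

In a functional assay on MDA-MB-231 cells (Homo sapiens) for antiproliferative activity, read by sulforhodamine B assay, with a stated time of 48 h (a higher number here means a weaker inhibitor, a lower number a stronger inhibitor), compound 1 `CCN(CC)C(=O)c1cccc(C2SCC(=O)N2c2ccccc2OC)c1` gives > 50000 nM as a limit and not a number. Compound 2 `C=CCN(CC=C)C(=O)c1cccc(C2SCC(=O)N2c2ccccc2OC)c1` gives > 50000 nM as a limit too. Among the compounds with values here, the only measured step is a step that the two limits leave unreadable from compound 1 to compound 2 and so offers no size to carry forward, with the limit of > 50000 nM in this assay, at which 2 of the 2 values shown sit, as all the evidence there is. Compound 3 `COc1ccccc1N1C(=O)CSC1c1cccc(C(=O)NCc2ccccc2)c1` puts benzylamino in place of diethylamino on a carbonyl carbon, a change counted as benzylamino in place of diethylamino on a carbonyl carbon in full. With no readable size to lean on, only a small step is expected, and an at least 1.2-fold lower number from compound 1 to compound 3 (0.09 log units; that floor lies within the scatter) is an estimate. Compound 3 is estimated to give 40000 nM with a likely range from 10000 nM to 100000 nM and may well return only a limit.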

Compound 3, half-maximal inhibitory concentration: > 25000 nM
Compound 3 ended at the assay's limit; the forecaster's own chance of this, stated with the estimate: 65%; the middle value lies beyond the limit too.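

Within the data shown here, compound 1, compound 2 and compound 3 all end at limits and not numbers, so no step among them can be read. Going by these compounds, what stays open is whether any group on that carbonyl carbon gives a readable value in this assay.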